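The source may report more compounds than this note shows. Statements on the series, on what has been measured and on what is new or still open speak of the compounds shown alone.

Compound 1 `O=c1[nH]c2ccccc2n1CCCCN1CCN(C(c2ccccc2)c2ccccc2)CC1`: in an assay on RPMI-8226 cells for antagonist activity at P2X purinoceptor 7 (Homo sapiens), read by calcium flux (a higher number here means a weaker inhibitor, a lower number a stronger inhibitor), compound 1 gives 180 nM.
Compound 2 `O=c1[nH]c2ccccc2n1C/C=C/CN1CCN(C(c2ccccc2)c2ccccc2)CC1`: compound 2 gives > 10000 nM, which is a limit of the assay and not a number.

Among the measured compounds shown here, compound 1 therefore holds the only number among the two results; the other result is the limit of > 10000 nM in this assay, at which 1 of the 2 values shown sits. Compound 3 `Cc1cccc2c1ccn2CCCCN1CCN(C(c2ccccc2)c2ccccc2)CC1` differs from compound 1 by a group of 10 heavy atoms (9 carbon, 1 nitrogen; one five-membered aromatic ring with 1 hetero atom, one six-membered aromatic ring of carbon only) in place of a group of 10 heavy atoms (7 carbon, 2 nitrogen, 1 oxygen; one five-membered aromatic ring with 2 hetero atoms, one six-membered aromatic ring of carbon only), on a saturated chain carbon, four bonds along the chain from an amine nitrogen in a ring. For the measured compounds named here, no measured pair carries this change, so its size is open; the group that enters holds no hydrogen-bond donor where the group that leaves held one. A loss of potency beyond the scatter is expected, with the step from compound 1 to compound 3 estimated at an 8.3-fold higher number from compound 1 to compound 3 (0.92 log units; beyond the scatter). Compound 3 is expected to give 1500 nM, between 300 nM and 8000 nM.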

Compound 3, half-maximal inhibitory concentration: 5300 nM
The estimate for compound 3 lay 3.5-fold (0.55 log units) below the measured number, within the range that was stated.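

With a 29-fold higher number from compound 1 to compound 3 (1.47 log units; beyond the scatter) in this assay, the step shows that potency at this position, on a saturated chain carbon, four bonds along the chain from an amine nitrogen in a ring, depends strongly on which ring group sits there, even though both groups have 10 heavy atoms. The group that enters has no hydrogen-bond donor, but it also differs from the group that leaves in other ways, so the donor alone cannot be singled out. Nothing shown accounts for this loss. As far as these compounds go, whether a urea or a carboxylic acid at this place would restore potency remains open, as does the effect of a longer chain.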